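The compounds below may be only part of what the source reports. "The series", "measured", "known", "first", "only" and "open" are said of these compounds alone.

Measured so far:
- Compound 1, `Cc1cc(=O)n(-c2ccc(F)c(F)c2)nc1C(=O)Nc1ccc(Oc2ncnc3ccsc23)cc1`: 9230 nM
- Compound 2, `Cc1cc(=O)n(-c2ccc(Br)cc2F)nc1C(=O)Nc1ccc(Oc2ncnc3sccc23)cc1`: 6300 nM
- Compound 3, `O=C(Nc1ccc(Oc2ncnc3ccsc23)c(F)c1)c1nn(-c2ccc(F)c(Cl)c2)ccc1=O`: 10600 nM

All three were tested in a functional assay on HepG2 cells (Homo sapiens) for cytotoxicity, read by MTT assay, with a stated time of 72 h; on this read-out higher numbers stand for weaker inhibition and lower numbers for stronger inhibition. Compound 3 gives the highest number of the three, but the gaps to compound 1 and to compound 2 both lie within the scatter of repeated measurements, so the three values cannot be told apart with confidence; they show that all three compounds inhibit the cells only weakly.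

Compound 4, `Cc1ccc(-n2ccc(=O)c(C(=O)Nc3ccc(Oc4ncnc5ccsc45)c(F)c3)n2)cc1`, has not yet been measured. It differs from compound 3 in one place: 4-methylphenyl in place of 3-chloro-4-fluorophenyl on an aromatic nitrogen. The rest of the molecule, including the amide linker and the shared core on the ether side, is unchanged.

Going by the values given here, no pair of measured compounds differs in exactly one place, so there is no measured step to lean on. The three measured values cluster closely, which suggests that changes of this kind on the aryl group shift the number little. The expectation is therefore a step from compound 3 to compound 4 of a 1.1-fold higher number from compound 3 to compound 4 (0.05 log units; within the scatter), that is, no change beyond the scatter, with a slight lean toward a higher number.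

On that basis compound 4 is estimated to give 12000 nM in this assay, with a likely range from 5000 nM to 30000 nM.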

Compound 4, half-maximal inhibitory concentration: 24300 nM
The estimate for compound 4 lay 2.0-fold (0.31 log units) below the measured number, within the range that was stated.
By their numbers in this assay, from the lowest: compounds 2, 1 and 3 (each within the scatter of the next); then compound 4.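

Putting 4-methylphenyl in place of 3-chloro-4-fluorophenyl on the aromatic nitrogen gives, in this assay, a 2.3-fold higher number from compound 3 to compound 4 (0.36 log units; beyond the scatter), a modest step but one beyond the scatter. The earlier compounds shown here could not show this, since no two of them differed in only one place and their close values said nothing about any single group. The aryl group on this nitrogen can therefore shift the number on its own, and this swap shifts it toward weaker inhibition of the cells, although nothing available explains why the number moves.

This single swap removes the chlorine and the fluorine and adds the methyl all at once, so the compounds shown cannot say which of these changes accounts for the step. Also open is how an unsubstituted phenyl, a 4-chlorophenyl, a 4-methoxyphenyl or an aryl ring carrying an amine or a carboxylic acid would read on this nitrogen, and whether the same swap would give a similar step on the other cores shown.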